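A pentyl-to-(cyclopentylmethyl)amino change on the carbonyl carbon

The source may report more compounds than this note shows. Statements on the series, on what has been measured and on what is new or still open speak of the compounds shown alone.

Measured so far:
Compound 1, `CCCCCC(=O)Nc1ccc(S(=O)(=O)Oc2ccccc2I)cc1`: 9600 nM
Compound 2, `CC(C)c1ccccc1OS(=O)(=O)c1ccc(NC(=O)CCCCl)cc1`: 3800 nM

In a functional assay on HT-1080 cells (Homo sapiens) for antiproliferative activity, read by sulforhodamine B assay, with a stated time of 48 h (on this read-out higher numbers stand for weaker inhibition and lower numbers for stronger inhibition), compound 1 gives 9600 nM, the highest of the two numbers, meaning the weaker inhibition; compound 2 gives 3800 nM, a lower number that lies beyond the usual scatter of this assay. Compound 2 differs from compound 1 in more than one place, so its number says nothing by itself about any single change.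

The unmeasured compound 3, `O=C(NCC1CCCC1)Nc1ccc(S(=O)(=O)Oc2ccccc2I)cc1`, keeps the core of compound 1 and alters only one part: (cyclopentylmethyl)amino in place of pentyl on a carbonyl carbon. Going by the values given here, no measured pair shows this same change, so there is nothing to lean on for its size or direction. Compound 3 is therefore expected to sit near compound 1, with a step of a 1.5-fold lower number from compound 1 to compound 3 (0.17 log units; within the scatter) that stays within or only slightly beyond the scatter. The estimate for compound 3 is 6500 nM, in a range from 1500 nM to 28000 nM.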

Compound 3, half-maximal inhibitory concentration: 6100 nM
Compound 3: middle estimate off by 1.1-fold (0.03 log units), on the high side, within the range that was stated.
By their numbers in this assay, from the lowest: compounds 2, 3 and 1 (each within the scatter of the next, the first and the last beyond it).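

In this assay, going by these compounds alone, the change at this position gives a 1.6-fold lower number from compound 1 to compound 3 (0.20 log units; within the scatter), the first comparison here in which only one part of the molecule differs. It shows that the carbonyl carbon can carry (cyclopentylmethyl)amino, with its five-membered carbon ring, added nitrogen and hydrogen-bond donor, in place of the open pentyl chain without a shift that stands clear of the scatter. Nothing measured here explains why the read-out stays so close across this change.

On these data alone, this single swap also brings in the ring and the nitrogen together, so the part each plays on its own remains open: a cyclopentylmethyl group without the nitrogen would separate them. How a phenyl ring, a decyl chain or a carboxylic acid would fare on the same carbonyl carbon is also unknown.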